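A few compounds are considered here, and "the series" means these few. Any claim that something is new, unique, unknown or untested is made for them only; others in the source may bear on it.

Compound 3 `O=C(C1CCCN(Cc2ccccc2F)C1)N1CCN(c2ccccc2Cl)CC1` was measured in a functional assay on a cell-free system (Platelet, plasma, Homo sapiens), with stated times of 4 min and 5.5 min, tested at 0.5 uM (a lower number here means a stronger effect, a higher number a weaker effect of the compound at the concentration tested), and gives 73%. Among the three numbers at hand it stands second highest: compound 1 `O=C(c1ccc[n+](Cc2ccc(Br)cc2)c1)N1CCN(c2ccccc2Cl)CC1` gives 78%, which lies within the scatter of compound 3, while compound 2 `O=C(C1CCCN(Cc2ccccc2)C1)N1CCN(c2ccccc2Cl)CC1` gives 26%, far below it. Compound 4 `O=C(C1CCCN(Cc2ccc(F)cc2)C1)N1CCN(c2ccccc2Cl)CC1` differs from compound 3 by 4-fluorophenyl in place of 2-fluorophenyl on a saturated chain carbon bound to an amine nitrogen in a ring. Within the data shown here, the one measured step that touches this part of the molecule is a number 47 percentage points higher from compound 2 to compound 3 (beyond the scatter); it shows that the fluorine matters a great deal, but nothing measured shows what moving it to another position does. A modest downward step, a number 11 percentage points lower from compound 3 to compound 4 (beyond the scatter), is therefore expected, with wide uncertainty around it. Compound 4 is estimated at 62%, between 35% and 85%.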

Compound 4, a percentage reported as activity, at one concentration (the size of the read-out at that concentration, not a potency): 67%
Beside the measured number, compound 4's estimate is 5 percentage points below it, within the range that was stated.
By their numbers in this assay, from the lowest: compound 2; then compounds 4, 3 and 1 (each within the scatter of the next, the first and the last beyond it).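

In this assay, the step of a number 6 percentage points lower from compound 3 to compound 4 (within the scatter) shows that 4-fluorophenyl and 2-fluorophenyl cannot be told apart here, so the fluorine's place on this ring has little visible effect. The step of a number 41 percentage points higher from compound 2 to compound 4 (beyond the scatter) shows that the large gap from the unsubstituted compound appears with either fluorine, not with just one placement. No evidence at hand speaks to what lies behind this. Still open, as far as these compounds go, is whether a chlorine or a methoxy group in place of the fluorine would give the same large step.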